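The source may hold more compounds than are shown below. What is called first, only, known or untested is meant among the compounds shown, and "the series" means these compounds.

In a functional assay on Bel7402/5-FU cells (Homo sapiens) for antiproliferative activity, read by MTT assay, with a stated time of 72 h (a higher number here means a weaker inhibitor, a lower number a stronger inhibitor), compound 1 (`C=C1C(=O)O[C@H]2[C@H]1CC/C(COC(=O)CCC(=O)NCCCCCCNC(=O)Cn1cc(F)c(=O)[nH]c1=O)=C\CC[C@@]1(C)O[C@@H]21`) gives > 20000 nM as a limit of the assay and not as a number. Among the measured compounds shown here, compound 2 (`C=C1C(=O)O[C@H]2[C@H]1CC/C(COC(=O)Cn1cc(F)c(=O)n(Cc3ccc(Br)cc3)c1=O)=C\CC[C@@]1(C)O[C@@H]21`) gives 3240 nM as the only actual number so far. Compound 3 (`C=C1C(=O)O[C@H]2[C@H]1CC/C(COC(=O)Cn1cc(F)c(=O)n(Cc3cc(F)ccc3F)c1=O)=C\CC[C@@]1(C)O[C@@H]21`) differs from compound 2 in one place (2,5-difluorophenyl in place of 4-bromophenyl on a saturated chain carbon bound to an aromatic nitrogen), with 2,5-difluorophenyl in place of 4-bromophenyl on a saturated chain carbon bound to an aromatic nitrogen. For the measured compounds named here, no measured step shows what this exchange does. The expected step of a 1.4-fold higher number from compound 2 to compound 3 (0.14 log units; within the scatter) is small and towards weaker inhibition, and it may not exceed the usual scatter. Compound 3 is estimated at 4500 nM in this assay, with an expected range from 1500 nM to 14000 nM for repeated measurements.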

Compound 3, half-maximal inhibitory concentration: 4610 nM
The estimate for compound 3 lay 1.0-fold (0.01 log units) below the measured number; the range from low to high includes it.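

In this assay, exchanging one halogenated phenyl group for the other gives a 1.4-fold higher number from compound 2 to compound 3 (0.15 log units; within the scatter), so this position accepts both halogenated phenyl groups without a change that can be told from the scatter. Nothing measured here bears on why this is so. Still open, as far as these compounds go, is whether a phenyl ring carrying an amine or a carboxylic acid would behave the same way. Among the compounds shown here, also open is what an unsubstituted benzyl group or a longer chain at this position would do, since this single step compares only two halogenated benzyl groups.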